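The source may hold more compounds than are shown below. What is called first, only, known or untested is meant among the compounds shown, and "the series" means these compounds.

Working notes, measured in an ADME assay on MT4 cells (Homo sapiens) for cytotoxicity, read by MTT assay, with a stated time of 96 h; a lower number here means that less compound is tolerated, a higher number that more compound is tolerated:

- Compound 1 `COc1nc2ccc(CSc3ccc(Cl)c(Cl)c3)cc2nc1OC`: 48000 nM.
- Compound 2 `COc1nc2ccc(CSc3ccc4ccccc4c3)cc2nc1OC`: > 100000 nM, a limit of the assay.
- Compound 3 `COc1nc2ccc(CSc3ccccn3)cc2nc1OC`: 28000 nM.

Among the compounds with values here, compound 3 stands at 28000 nM, and the only other number lies close to it: a 1.7-fold lower number from compound 1 to compound 3 (0.23 log units; within the scatter). Compound 2 sits at the limit of > 100000 nM in this assay, at which 1 of the 3 values shown sits.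

Compound 4 `COc1nc2ccc(CSc3ccc(C(=O)O)cn3)cc2nc1OC` carries carboxy in place of hydrogen on an aromatic carbon of compound 3: carboxy in place of hydrogen on an aromatic carbon. Within the data shown here, no measured step adds this group. The closest guide is the exchange on the sulfur, a 1.7-fold lower number from compound 1 to compound 3 (0.23 log units; within the scatter), so no step beyond the scatter is expected in this assay, with a slight lean towards a higher number. The expected step is a 1.4-fold higher number from compound 3 to compound 4 (0.15 log units; within the scatter). Compound 4 is estimated at 40000 nM, with an expected range of 15000 nM to 100000 nM.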

Compound 4, half-maximal cytotoxic concentration: > 100000 nM
Compound 4: no number, only a limit; the forecaster's own chance of this, stated with the estimate: 20%; at least 2.5-fold (0.39 log units) between middle value and limit.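

Carboxy on this aromatic carbon, two atoms from the ring nitrogen, gives the only step shown beyond the scatter in this assay: an at least 3.5-fold higher number from compound 3 to compound 4 (0.55 log units; beyond the scatter). Within the data shown here, the exchange on the sulfur stayed within the scatter, a 1.7-fold lower number from compound 1 to compound 3 (0.23 log units; within the scatter), so this ring position shows a response that the earlier compounds did not. Compound 4 gives only a limit, not a number: the limit of > 100000 nM in this assay, at which 2 of the 4 values shown sit.

Going by these compounds, the true size of the step stays open. So does whether an amine or a methyl ester on the same carbon would shift the number as carboxy does.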